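The compounds below may be only part of what the source reports. "The series", "measured", "known", "first", "only" and "open" are said of these compounds alone.

In a functional assay on PANC-1 cells (Homo sapiens), read by microscopy, crystal violet staining and transwell migration, with a stated time of 18 h, in the presence of a further agent that is not named here (a higher number here means a weaker inhibitor, a lower number a stronger inhibitor), the measured compounds are:

- compound 1 `COc1ccc(-c2nc(C)nn2-c2cccc(C(=O)NCCCOc3ccccc3)c2)cc1`: 3120 nM
- compound 2 `COc1ccc(-c2nc(C)nn2-c2cccc(C(=O)NCCOCc3ccccc3)c2)cc1`: 9340 nM
- compound 3 `COc1ccc(-c2ncnn2-c2cccc(C(=O)NCCCCc3ccccc3)c2)cc1`: > 20000 nM (a limit, not a number)

Compound 3 therefore has no exact position on the scale: the limit of > 20000 nM in this assay, at which 1 of the 3 values shown sits.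

Compound 4 `CCCCc1nc(-c2ccc(OC)cc2)n(-c2cccc(C(=O)NCCCCc3ccccc3)c2)n1` keeps the chain of compound 3 and puts butyl in place of hydrogen on an aromatic carbon.

Within the data shown here, no measured step isolates this change. The only one, a 3.0-fold higher number from compound 1 to compound 2 (0.48 log units; beyond the scatter), is a modest step in the chain, elsewhere in the molecule. Compound 1 carries methyl on that aromatic carbon and gives 3120 nM, and compound 2 also carries it and gives 9340 nM. Both also differ from compound 3 in the chain, so they offer only a loose guide.

A move towards a lower number in this assay is expected, of uncertain size, and compound 4 could still stay at the limit. The expected step is an at least 2.5-fold lower number from compound 3 to compound 4 (0.39 log units; beyond the scatter). For compound 4 the estimate is 8000 nM, with an expected range of 2500 nM to 20000 nM.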

Compound 4, half-maximal inhibitory concentration: 16800 nM
Beside the measured number, compound 4's estimate is 2.1-fold (0.32 log units) below it; the measured number falls inside the stated range.
By their numbers in this assay, from the lowest: compound 1; then compounds 2 and 4 (each within the scatter of the next). At a limit, above all of these: compound 3.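

With butyl in place of hydrogen on this aromatic carbon, compound 4 gives a measured number in this assay, 16800 nM, so a butyl group at this position still leaves a readable inhibitor. The step is an at least 1.1-fold lower number from compound 3 to compound 4 (0.07 log units; that floor lies within the scatter), and this floor alone does not establish a real gain. Compound 3 has only a limit, not a number: the limit of > 20000 nM in this assay, at which 1 of the 4 values shown sits.

Methyl on this carbon appears only in compounds with other chains, so what the smaller group would do alongside the chain of compound 3 remains open. The compounds shown also leave open how a longer chain such as hexyl, or an amine or a carboxylic acid, would behave on this aromatic carbon.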